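The source may hold more compounds than are shown below. What is called first, only, known or untested is meant among the compounds shown, and "the series" means these compounds.

Compound 1, `CCCCc1cnc(C(CCCO)Cc2ccc(-c3ccccc3C(=O)O)cc2)[nH]1`: 1900 nM
Compound 2, `N#Cc1ccccc1Cc1cnc(CCc2ccc(-c3ccccc3C(=O)O)cc2)[nH]1`: 5480 nM
Compound 3, `CCCCc1cnc(C(Cc2ccc(-c3ccccc3C(=O)O)cc2)C(C)C)[nH]1`: 4620 nM

Three compounds sharing one core were tested in an in vitro functional assay on cells for agonist activity at Bombesin receptor subtype-3 (Homo sapiens), read by luminescence and calcium flux; on this read-out lower numbers stand for an effect already at smaller amounts and higher numbers for an effect only at larger amounts of compound. Compound 2 gives the highest number of the three; its value lies within the scatter of compound 3 but beyond it relative to compound 1, which gives the lowest number of the set. Within the data shown here, the only measured step that keeps a single difference is a 2.4-fold higher number from compound 1 to compound 3 (0.39 log units; beyond the scatter), and it concerns the saturated chain carbon, not the group on the imidazole ring.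

Compound 4, `O=C(O)c1ccccc1-c1ccc(CCc2ncc(CC3CC3)[nH]2)cc1`, has not been measured. It differs from compound 2 as follows: cyclopropyl in place of 2-cyanophenyl on a saturated chain carbon bound to an aromatic carbon. Among the measured compounds shown here, no measured pair isolates a change at this place, so the measured step gives no direct guidance; the data only show that compounds 2 and 3, with different groups on the imidazole ring and a different chain, sit within the scatter of each other.

In this assay compound 4 is therefore expected to give about 5000 nM, with a range from 1500 nM to 16000 nM. The expected change is a 1.1-fold lower number from compound 2 to compound 4 (0.04 log units; within the scatter), which is estimated to fall within the scatter rather than beyond it.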

Compound 4, half-maximal effective concentration: 1000 nM
The estimate for compound 4 lay 5.0-fold (0.70 log units) above the measured number; measured number outside the range, below it.
By their numbers in this assay, from the lowest: compounds 4 and 1 (each within the scatter of the next); then compounds 3 and 2 (each within the scatter of the next).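

In this assay, among these compounds, the place on a saturated chain carbon bound to an aromatic carbon turns out to matter: cyclopropyl in place of 2-cyanophenyl gives a 5.5-fold lower number from compound 2 to compound 4 (0.74 log units; beyond the scatter) and this is the first measured step at this place. The change swaps 8 heavy atoms, including an aromatic ring and a nitrile, for 3 heavy atoms in a three-membered ring, so in this pair neither the aromatic ring nor the nitrile is needed for the lower number. Nothing available explains the step, and this one pair cannot separate the contributions of the two features.

Going by these compounds, whether a plain phenyl, a cyclobutyl or a longer chain at this place would give a number close to that of compound 4 remains open. On these data alone, it is also open whether cyclopropyl would give a similar step on a core carrying the 3-hydroxypropyl group of compound 1.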